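Cyano in place of nitro on the shared core

The source may report more compounds than this note shows. Statements on the series, on what has been measured and on what is new or still open speak of the compounds shown alone.

Measured in a toxicity assay on THP-1 cells (Homo sapiens) for inhibition; a higher number here means that more compound is tolerated, a lower number that less compound is tolerated:
compound 1 `COc1ccc(-c2cnc(NC(=O)c3ccc(F)cc3)n2C)cc1`: >= 50000 nM (a limit)
compound 2 `COc1ccc(-c2cnc(NC(=O)c3ccc([N+](=O)[O-])cc3)n2C)cc1`: > 100000 nM (a limit)

Compound 2 stands at > 100000 nM, which is a limit and not a number. Compound 3 `COc1ccc(-c2cnc(NC(=O)c3ccc(C#N)cc3)n2C)cc1` differs from it in one place: cyano in place of nitro on an aromatic carbon. Going by the values given here, the only measured step bearing on this change is a step that the two limits leave unreadable from compound 1 to compound 2, so no size can be carried over from it. No step beyond the scatter is therefore expected in this assay, in either direction. The expected step is a number no higher from compound 2 to compound 3 (the limit leaves the size open). For compound 3 the estimate is 100000 nM, with an expected range from 50000 nM to 200000 nM.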

Compound 3, half-maximal cytotoxic concentration: > 100000 nM
Compound 3: no number, only a limit; the forecaster's own chance of this, stated with the estimate: 80%; the middle value sits exactly at the limit.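

In this assay, going by these compounds alone, compound 1, compound 2 and compound 3 all carry limits and not numbers; no step among them can be read. The compounds shown leave open whether fluoro, nitro and cyano differ at all in this assay.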